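The source may report more compounds than this note shows. Statements on the series, on what has been measured and on what is new or still open speak of the compounds shown alone.

Measured in a functional assay on SK-BR-3 cells (Homo sapiens) for antiproliferative activity, read by MTT assay, with a stated time of 72 h; on this read-out lower numbers stand for stronger inhibition and higher numbers for weaker inhibition:
- compound 1 `CCN1CCN(c2cc(C)c3cc(NC(=O)c4ccc(F)cc4)ccc3n2)CC1`: 19800 nM
- compound 2 `CNc1cc(C)c2cc(NC(=O)c3ccc(Cl)c(Cl)c3)ccc2n1`: 6350 nM
- compound 3 `Cc1cc(N(C)C)nc2ccc(NC(=O)c3ccc(Cl)c(Cl)c3)cc12`: > 50000 nM, a limit and not a number

Compound 3 gives no number on this scale, only (the limit of > 50000 nM in this assay, at which 1 of the 3 values shown sits).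

Compound 4 `Cc1cc(N2CCN(C(C)C)CC2)nc2ccc(NC(=O)c3ccc(Cl)c(Cl)c3)cc12` carries 4-isopropylpiperazin-1-yl in place of dimethylamino on an aromatic carbon, next to the ring nitrogen (4-isopropylpiperazin-1-yl in place of dimethylamino on an aromatic carbon).

Within the data shown here, one measured step bears on this place: an at least 7.8-fold higher number from compound 2 to compound 3 (0.89 log units; beyond the scatter). It shows that this assay responds to a change on that nitrogen. Among the measured compounds shown here, compound 1, the only measured compound with a six-membered non-aromatic ring there, gives 19800 nM, although its amide side differs. On that basis a move to a lower number, beyond the scatter, is expected, with the expected step being an at least 5.0-fold lower number from compound 3 to compound 4 (0.69 log units; beyond the scatter). For compound 4 the estimated value is 10000 nM, with an expected range of 2000 nM to 45000 nM.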

Compound 4, half-maximal inhibitory concentration: 6680 nM
For compound 4 the middle estimate is 1.5-fold (0.18 log units) above the measured one, within the range that was stated.
By their numbers in this assay, from the lowest: compounds 2 and 4 (each within the scatter of the next); then compound 1. At a limit, above all of these: compound 3.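

In this assay, losing the hydrogen on the attached nitrogen does not by itself mark a dead end at this position: 4-isopropylpiperazin-1-yl in place of dimethylamino gives an at least 7.4-fold lower number from compound 3 to compound 4 (0.87 log units; beyond the scatter). The value of compound 3 is a limit and not a number: the limit of > 50000 nM in this assay, at which 1 of the 4 values shown sits. With 4-isopropylpiperazin-1-yl in place of methylamino the step is a 1.1-fold higher number from compound 2 to compound 4 (0.02 log units; within the scatter), so no difference can be read between these two groups.

From the compounds shown here alone, it remains open whether the isopropyl group matters or the ring alone suffices. An unsubstituted piperazine or a morpholine in the same place would separate the two.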